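Ethyl to isopropyl thioester on a dihydropyrimidinone scaffold

This account rests on a few compounds, and the source may have more. Where it says the series, first, only, none or still open, it means among the compounds named here.

Compound 1 `CC1=C(C(=O)OC(C)C)C(c2ccoc2)NC(=O)N1C` is measured in an assay on membranes from HEK293 cells for displacement of a labelled ligand from adenosine receptor A2b (Homo sapiens), read by scintillation counting, with a stated time of 30 min, tested at 1 uM (a higher number here means more inhibition at the concentration tested (going by the name of the read-out), a lower number less inhibition), and gives 37%. Compound 2 `CC1=C(C(=O)OC(C)(C)C)C(c2ccoc2)NC(=O)N1C` carries methyl in place of hydrogen on a saturated chain carbon bound to an oxygen next to a carbonyl group and two saturated chain carbons, and in this assay compound 2 gives 16%; the step of a number 21 percentage points lower from compound 1 to compound 2 (beyond the scatter). Compound 3 `CCSC(=O)C1=C(C)NC(=O)NC1c1cccs1` has a different core; the difference between the core of compound 3 and the core of compound 1 is not broken down here. In this assay compound 3 gives 1%, the lowest of the three numbers and beyond the scatter from both others.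

Compound 4 `CC1=C(C(=O)SC(C)C)C(c2cccs2)NC(=O)N1` is not yet measured; it differs from compound 3 by methyl in place of hydrogen on a saturated chain carbon bound to a saturated chain carbon and a sulfur. Among the compounds with values here, this is the same kind of change as the one from compound 1 to compound 2, though not the same: there the place was on a saturated chain carbon bound to an oxygen next to a carbonyl group and two saturated chain carbons, here it is on a saturated chain carbon bound to a saturated chain carbon and a sulfur. Given that the earlier step lowered the read-out, and because compound 3 already stands at 1%, the expected step is a number 1 percentage points higher from compound 3 to compound 4 (within the scatter), with little room to fall further. Compound 4 is therefore estimated at 2%, between -6% and 12%.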

Compound 4, a percentage reported as inhibition, at one concentration (the size of the read-out at that concentration, not a potency): 1%
Beside the measured number, compound 4's estimate is 1 percentage points above it; the measured number falls inside the stated range.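

In this assay, methyl in place of hydrogen, which turns ethylsulfanyl into isopropylsulfanyl, gives no change at the digits printed from compound 3 to compound 4 (within the scatter). Set beside the earlier step, the same kind of change does not carry over at the same size from one core to the other: the same change on two cores in this assay, a number 21 percentage points lower (beyond the scatter) from compound 1 to compound 2 and no change at the digits printed (within the scatter) from compound 3 to compound 4, 21 percentage points apart, beyond the scatter of two such steps This does not show that the change is harmless in general, nor that the core alone sets the outcome: compound 3 stands at 1%, where a lowering of the earlier size could not show, and the two steps also sit at different places, one on a carbon in a chain bound to an oxygen and the other on a carbon bound to a sulfur.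

The compounds shown leave open how this methyl would read on a compound of this series with a higher starting number and the sulfur link kept in place. They also leave open what a longer chain, a cyclopropyl group or an amine would do in place of the isopropyl.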